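The source may hold more compounds than are shown below. What is called first, only, known or untested is meant among the compounds shown, and "the series" means these compounds.

Measured compounds:
compound 1 `Nc1ncnc2c1ncn2C1C(O)C(O)C2(COP(=O)(O)OP(=O)(O)OP(=O)(O)O)CC12` gives 91 nM in a functional assay for agonist activity at P2Y purinoceptor 2 (Homo sapiens), read by inositol phosphate accumulation; a higher number here means that more compound is needed for the effect, a lower number that less compound is needed
compound 2 `Nc1nc(Cl)nc2c1ncn2C1C(O)C(O)[C@@]2(COP(=O)(O)OP(=O)(O)OP(=O)(O)O)C[C@@H]12` gives 1900 nM in this assay
compound 3 `CNc1ncnc2c1ncn2C1C(O)C(O)[C@@]2(COP(=O)(O)OP(=O)(O)OP(=O)(O)O)C[C@@H]12` gives 197 nM in this assay

Compound 3 stands second highest of the three numbers in this assay. Its nearest neighbour is compound 1, whose number is lower by an amount beyond the scatter; compound 2 lies furthest away, with a number well above it. Within the data shown here, the only single-place step recorded among the measured compounds is a 9.6-fold lower number from compound 2 to compound 3 (0.98 log units; beyond the scatter), which swaps the chloro-bearing core of compound 2 for the methylamino-bearing core of compound 3.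

Compound 4 `CNc1nc(Cl)nc2c1ncn2C1C(O)C(O)[C@@]2(COP(=O)(O)OP(=O)(O)OP(=O)(O)O)C[C@@H]12` carries chloro in place of hydrogen on an aromatic carbon. This is the same chloro group that distinguishes compound 2 from compound 1, and those two values show a markedly higher number once the chloro is present: compound 1 gives 91 nM, whereas compound 2 gives 1900 nM. The step of a 9.6-fold lower number from compound 2 to compound 3 (0.98 log units; beyond the scatter) points the same way, since removing the chloro while adding the methylamino lowered the number by a modest amount. Compound 4 is therefore expected to show a higher number than compound 3, with an estimated step of a 15-fold higher number from compound 3 to compound 4 (1.18 log units; beyond the scatter). The estimate for compound 4 in this assay is 3000 nM, in a range from 1000 nM to 9000 nM.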

Compound 4, half-maximal effective concentration: 8400 nM
Beside the measured number, compound 4's estimate is 2.8-fold (0.45 log units) below it; the measured number falls inside the stated range.
By their numbers in this assay, from the lowest: compound 1; then compound 3; then compound 2; then compound 4.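

In this assay, the chloro group on the aromatic carbon between two ring nitrogen atoms now stands alone as a single change, and it gives a 43-fold higher number from compound 3 to compound 4 (1.63 log units; beyond the scatter) on the methylamino-bearing core, a large step. With the chloro present, methyl in place of hydrogen on the nitrogen gives a 4.4-fold higher number from compound 2 to compound 4 (0.65 log units; beyond the scatter) as well, so this modest step runs in the same direction, and the earlier step from the chloro-bearing core to the methylamino-bearing core, which changed two places at once, can now be read as the net of two opposing changes. Nothing in the data shown accounts for the size of either step.

The compounds shown leave open how a fluoro, bromo or amino group on the same aromatic carbon would read in this assay, and so whether the large step is particular to chloro. They also leave open whether an ethyl group or a longer chain on the nitrogen would extend the rise seen with methyl, and whether the size of that rise holds on a core without the chloro.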